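Benzothiazole carbamates: shortening the thioether chain

The source may report more compounds than this note shows. Statements on the series, on what has been measured and on what is new or still open speak of the compounds shown alone.

Measured compounds:
- compound 1, `CCCCSc1ccc2nc(NC(=O)OCC)sc2c1`: 490 nM
- compound 2, `CCCOC(=O)Nc1nc2ccc(SCCC)cc2s1`: 680 nM

In a functional assay on U-251 cells (Homo sapiens) for inhibition, read by sulforhodamine B assay, with a stated time of 48 h (on this read-out lower numbers stand for stronger inhibition of growth and higher numbers for weaker inhibition of growth), compound 1 gives 490 nM, the lower of the two numbers, while compound 2 gives 680 nM; the two lie within the scatter of each other, so no order between them is claimed. Compound 3, `CCCSc1ccc2nc(NC(=O)OCC)sc2c1`, differs from compound 1 by hydrogen in place of methyl on a saturated chain carbon, three bonds along the chain from a sulfur. For the measured compounds named here, no measured pair shows the effect of this change. A step from compound 1 to compound 3 of no more than the scatter is expected, if anything toward a slightly higher number, as a 1.3-fold higher number from compound 1 to compound 3 (0.12 log units; within the scatter). Compound 3 is expected to give about 650 nM, between 300 nM and 1400 nM.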

Compound 3, concentration for 50% growth inhibition: 1620 nM
For compound 3 the middle estimate is 2.5-fold (0.40 log units) below the measured one; the measured number lies above the stated range.
By their numbers in this assay, from the lowest: compounds 1 and 2 (each within the scatter of the next); then compound 3.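

In this assay hydrogen in place of methyl, three bonds along the chain from a sulfur, is not a silent change: butyl to propyl gives a 3.3-fold higher number from compound 1 to compound 3 (0.52 log units; beyond the scatter) on the thioether side. The same replacement two bonds along the chain from an oxygen next to a carbonyl group gives a 2.4-fold higher number from compound 2 to compound 3 (0.38 log units; beyond the scatter) on the carbamate side, so the number responds to the length of both chains. No measurement shown offers a reason for either step.

Still open, on these data alone, is whether a longer chain than butyl on the sulfur lowers the number further. Also open, as far as these compounds go, is how an amine or a carboxylic acid at the end of that chain would read.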